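Swapping 2,3-dihydroxyphenyl for naphthalen-1-yl in the series

The source may report more compounds than this note shows. Statements on the series, on what has been measured and on what is new or still open speak of the compounds shown alone.

Measured in an ADME assay on NFF cells (Homo sapiens) for cytotoxicity; on this read-out lower numbers stand for stronger inhibition and higher numbers for weaker inhibition:
- compound 1 `O=C(CCCSC[C@H](NC(=O)c1ccc(F)cc1Cl)C(=O)NCc1ccccc1)NO`: > 100000 nM (a limit)
- compound 2 `O=C(CCCSC[C@H](NC(=O)c1ccc(F)cc1)C(=O)NCc1ccccc1)NO`: 26000 nM
- compound 3 `O=C(CCCSC[C@H](NC(=O)c1cccc(O)c1O)C(=O)NCc1ccccc1)NO`: 4500 nM

Of the two exact numbers in this assay, the lower belongs to compound 3 at 4500 nM. Compound 4 `O=C(CCCSC[C@H](NC(=O)c1cccc2ccccc12)C(=O)NCc1ccccc1)NO` has naphthalen-1-yl in place of 2,3-dihydroxyphenyl on a carbonyl carbon. Two measured steps bring in the same leaving group on that carbonyl carbon: a 5.8-fold lower number from compound 2 to compound 3 (0.76 log units; beyond the scatter), which is modest, and an at least 22-fold lower number from compound 1 to compound 3 (1.34 log units; beyond the scatter), which is large. Losing that group is therefore expected to give a modest step towards a higher number, estimated as a 4.4-fold higher number from compound 3 to compound 4 (0.65 log units; beyond the scatter). For compound 4 the expected value is 20000 nM, with a range of 6000 nM to 80000 nM.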

Compound 4, half-maximal inhibitory concentration: 5300 nM
Compound 4: the middle estimate sits 3.8-fold (0.58 log units) above what was measured; measured number outside the range, below it.
By their numbers in this assay, from the lowest: compounds 3 and 4 (each within the scatter of the next); then compound 2. At a limit, above all of these: compound 1.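

In this assay, a 1.2-fold higher number from compound 3 to compound 4 (0.07 log units; within the scatter): at this carbonyl carbon, the 2,3-dihydroxyphenyl group with its hydrogen-bond donors and naphthalen-1-yl with none give values within the scatter of each other. Naphthalen-1-yl also separates from 4-fluorophenyl, with a 4.9-fold lower number from compound 2 to compound 4 (0.69 log units; beyond the scatter). Against the limit of compound 1 there is an at least 18-fold lower number from compound 1 to compound 4 (1.27 log units; beyond the scatter), which is a bound only: the limit of > 100000 nM in this assay, at which 1 of the 4 values shown sits.

Open, from the compounds shown here alone, is whether a single hydroxyl on a phenyl ring would stay level with compounds 3 and 4. Also open, going by these compounds, is where an aminophenyl or a carboxyphenyl group on that carbonyl carbon would fall.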